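The source may hold more compounds than are shown below. What is called first, only, known or untested is meant among the compounds shown, and "the series" means these compounds.

Working notes on the series. In a functional assay on HL-60 cells (Homo sapiens) for cytotoxicity, read by MTT assay, with a stated time of 48 h (a higher number here means a weaker inhibitor, a lower number a stronger inhibitor), compound 2 (`Fc1cccc(Nc2nc(-c3cccc(F)c3)nc3ccc(F)cc23)c1`) gives 43100 nM. Compound 1 (`COc1ccc(Nc2nc(-c3cccc(F)c3)nc3ccc(F)cc23)cc1`) gives 38600 nM, and these two numbers, the only ones so far, lie within the scatter of each other. Compound 3 (`Fc1cccc(-c2nc(Nc3cccc(Br)c3)c3cc(F)ccc3n2)c1`) gives > 50000 nM, which is a limit of the assay and not a number.

The next change leads to compound 4 (`Oc1ccc(Nc2nc(-c3cccc(F)c3)nc3ccc(F)cc23)cc1`), with 4-hydroxyphenyl in place of 3-fluorophenyl on a nitrogen on an aromatic ring. Among the measured compounds shown here, three measured steps bear on this place. Replacing the 4-methoxyphenyl group with 3-bromophenyl gave an at least 1.2-fold higher number from compound 1 to compound 3 (0.11 log units; that floor lies within the scatter), and bromo in place of fluoro gave an at least 1.1-fold higher number from compound 2 to compound 3 (0.06 log units; that floor lies within the scatter). Both of these are floors only, so they set no size for a real step. For the measured compounds named here, no measured compound carries the 4-hydroxyphenyl group, so there is no direct read on it.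

The closest guide is a 1.1-fold higher number from compound 1 to compound 2 (0.05 log units; within the scatter), a change of group on the same nitrogen. No step beyond the scatter is therefore expected in this assay, and no direction is favoured. The estimated step is a 1.3-fold lower number from compound 2 to compound 4 (0.13 log units; within the scatter). For compound 4 the estimated value is 32000 nM, with an expected range of 12000 nM to 55000 nM.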

Compound 4, half-maximal inhibitory concentration: > 50000 nM
Compound 4: no number, only a limit; the forecaster's own chance of this, stated with the estimate: 25%; middle value at least 1.5-fold (0.19 log units) away from the limit.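

In this assay the 4-hydroxyphenyl group on this nitrogen yields only a limit of the assay and not a number, so the series now holds a second compound there: the limit of > 50000 nM in this assay, at which 2 of the 4 values shown sit. The change from the 3-fluorophenyl group reads as an at least 1.1-fold higher number from compound 2 to compound 4 (0.06 log units; that floor lies within the scatter), and hydrogen in place of methyl on the oxygen reads as an at least 1.2-fold higher number from compound 1 to compound 4 (0.11 log units; that floor lies within the scatter), both floors that set no size for a real step. Among the compounds shown here, the second of these is the first pair to differ only on that oxygen and not by a change of the whole group on the nitrogen, while the step between compound 3 and compound 4 cannot be read, since both ends are limits.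

On these data alone, whether a 4-aminophenyl or a 4-carboxyphenyl group on this nitrogen, or a longer chain in place of methyl on the oxygen of compound 1, would give a step beyond the scatter stays open. Also open, as far as these compounds go, is how far compound 3 and compound 4 lie past the limit, so no order between them can be stated.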